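The source may hold more compounds than are shown below. What is called first, only, known or untested is meant among the compounds shown, and "the series" means these compounds.

Three compounds have been measured in an assay on A7R5 cells for displacement of a labelled ligand from Endothelin-1 receptor (Rattus norvegicus); a higher number here means a weaker inhibitor, a lower number a stronger inhibitor:
compound 1 `Cc1onc(NS(=O)(=O)c2ccc(N)cc2)c1I` gives 11000 nM;
compound 2 `COc1cccc(Sc2c(NS(=O)(=O)c3ccc(C(C)(C)C)cc3)noc2CO)c1` gives 6200 nM;
compound 3 `COc1cccc(Sc2c(NS(=O)(=O)c3ccc(C(C)(C)C)cc3)noc2CCCC(=O)O)c1` gives 4300 nM.

Among these three numbers compound 1 has the highest. Its nearest neighbour is compound 2, and the gap between the two lies within the scatter, so nothing separates them; the gap to compound 3 is larger and lies beyond the scatter. Going by the values given here, the one step that can be traced between two measured compounds runs a 1.4-fold lower number from compound 2 to compound 3 (0.16 log units; within the scatter) and touches only a chain on the far side of the shared core.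

Compound 4 `Cc1onc(NS(=O)(=O)c2ccc(C(C)(C)C)cc2)c1I` differs from compound 1 in a single place: tert-butyl in place of amino on an aromatic carbon. Among the compounds with values here, no measured pair isolates this change. Compounds 2 and 3 both carry a tert-butyl group on the same ring, and compound 3 sits beyond the scatter under compound 1 while compound 2 does not, but both also differ from compound 1 elsewhere, so their values cannot be read as the effect of the tert-butyl alone. The step of a 1.4-fold lower number from compound 2 to compound 3 (0.16 log units; within the scatter) concerns a different part of the molecule and gives no guidance either. On this thin ground a modest move toward a lower number is expected, a 2.2-fold lower number from compound 1 to compound 4 (0.34 log units; beyond the scatter), with wide uncertainty. Compound 4 is therefore estimated at 5000 nM in this assay, with a range from 1500 nM to 20000 nM.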

Compound 4, half-maximal inhibitory concentration: > 100000 nM
Compound 4: a limit, no number (the forecaster's own chance of this, stated with the estimate: 5%); middle value at least 20-fold (1.30 log units) from the limit.
By their numbers in this assay, from the lowest: compounds 3, 2 and 1 (each within the scatter of the next, the first and the last beyond it). At a limit, above all of these: compound 4.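

On an aromatic carbon para to a large group, putting tert-butyl in place of amino gives an at least 9.0-fold higher number from compound 1 to compound 4 (0.95 log units; beyond the scatter) in this assay, and this is the first pair shown that isolates this position. The earlier compounds shown here could not reveal even the direction of this change, and it now points toward weaker inhibition, so on the core of compound 1 a tert-butyl group at this position does not bring a lower number. The size of the step remains a minimum, as the result for compound 4 is a limit and not a number: the limit of > 100000 nM in this assay, at which 1 of the 4 values shown sits.

The compounds shown leave open how far the step extends, and whether it comes from the loss of the amino group, the arrival of the tert-butyl group, or both. They also cannot say how a smaller group such as ethyl, or a dimethylamino group or a nitrile, would behave on this same aromatic carbon, or whether the same swap would have a similar effect on the cores of compound 2 and compound 3.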